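Replacing a fluorinated ring with 1H-pyrazol-1-yl

The source may hold more compounds than are shown below. What is called first, only, known or untested is meant among the compounds shown, and "the series" means these compounds.

Compound 1 `Oc1ccc(Cn2cnc(F)c2)c2cccnc12`: 2200 nM
Compound 2 `CC(=O)Oc1ccc(Cn2ccnc2)c2cccnc12`: 28500 nM

Among the compounds with values here, in a functional assay on MV4-11 cells (Homo sapiens) for antiproliferative activity, read by luminescence, with a stated time of 72 h (a lower number here means a stronger inhibitor, a higher number a weaker inhibitor), compound 1 gives 2200 nM, the lower of the two numbers measured so far. The number for compound 2 is higher, and the gap lies beyond the usual scatter. These two compounds differ in more than one place, so their values do not isolate any single change.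

Compound 3 `Oc1ccc(Cn2cccn2)c2cccnc12` keeps the core of compound 1 but changes the group on a saturated chain carbon bound to an aromatic carbon: a group of 5 heavy atoms (3 carbon, 2 nitrogen; one five-membered aromatic ring with 2 hetero atoms) in place of a group of 6 heavy atoms (3 carbon, 2 nitrogen, 1 fluorine; one five-membered aromatic ring with 2 hetero atoms), on a saturated chain carbon bound to an aromatic carbon. The entering group is 1H-pyrazol-1-yl. Within the data shown here, both groups contain one five-membered aromatic ring with 2 hetero atoms, but no measured pair shows what this exchange does. A small move towards a weaker number, within the usual scatter, is therefore expected, with an estimated 1.4-fold higher number from compound 1 to compound 3 (0.13 log units; within the scatter). Compound 3 is expected at about 3000 nM, within an estimated range of 1000 nM to 9000 nM.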

Compound 3, half-maximal inhibitory concentration: 1600 nM
Compound 3: middle estimate off by 1.9-fold (0.27 log units), on the high side; the range from low to high includes it.
By their numbers in this assay, from the lowest: compounds 3 and 1 (each within the scatter of the next); then compound 2.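

In this assay, putting 1H-pyrazol-1-yl in place of the fluorine-bearing group on a saturated chain carbon bound to an aromatic carbon gives a 1.4-fold lower number from compound 1 to compound 3 (0.14 log units; within the scatter). Within the data shown here, this is the first single change that can be read at this place, and it shows that this exchange, which removes the fluorine and keeps one five-membered aromatic ring with 2 hetero atoms, leaves the number indistinguishable from that of compound 1. No other data shown bear on this result.

The compounds shown leave open what happens at this place when the ring gives way to a different kind of group, such as an amine, a carboxylic acid or a longer chain. Compound 2 differs from compound 3 in more than one place, so its higher number cannot be traced to any single change.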